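Tosyl capping of the amino group in a long-chain threoninamide

This account rests on a few compounds, and the source may have more. Where it says the series, first, only, none or still open, it means among the compounds named here.

This series consists of threonine-derived amides bearing long saturated chains, tested in a functional assay on A-431 cells (Homo sapiens) for cytotoxicity, read by MTT assay, with a stated time of 48 h; a lower number here means a stronger inhibitor, a higher number a weaker inhibitor. Compound 1 `CCCCCCCCCCCCCCNC(=O)[C@@H](N)[C@@H](C)O` gives 14600 nM, compound 2 `CCCCCCCCCCCCCCCCCCNC(=O)[C@@H](N)[C@@H](C)O` gives 21300 nM, and compound 3 `CCCCCCCCCCCCCCNC(=O)[C@@H](NC(=O)c1nccc2ccccc12)[C@@H](C)O` gives 23000 nM. Among the compounds with values here, of these three numbers, that of compound 2 is the second highest, although all three lie within the scatter of one another; the only measured step, a 1.5-fold higher number from compound 1 to compound 2 (0.16 log units; within the scatter), concerns chain length and not the amine.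

Compound 4 `CCCCCCCCCCCCCCCCCCNC(=O)[C@@H](NS(=O)(=O)c1ccc(C)cc1)[C@@H](C)O` differs from compound 2 by (4-methylphenyl)sulfonyl in place of hydrogen on an amine nitrogen. Within the data shown here, no measured step covers this exact change. The nearest comparison is compound 3 against compound 1, where an acyl group on the same amine nitrogen gives numbers that are indistinguishable within the scatter. On that basis the step from compound 2 to compound 4 in this assay is expected to be small, with no clear direction, as in a 1.2-fold higher number from compound 2 to compound 4 (0.07 log units; within the scatter). Compound 4 is therefore estimated at 25000 nM, within a range from 8000 nM to 80000 nM.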

Compound 4, half-maximal inhibitory concentration: 34000 nM
Compound 4: middle estimate off by 1.4-fold (0.13 log units), on the low side, and the stated range covers the measured number.
By their numbers in this assay, from the lowest: compounds 1, 2, 3 and 4 (each within the scatter of the next, the first and the last beyond it).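

On the amine nitrogen of compound 2, (4-methylphenyl)sulfonyl in place of hydrogen gives a 1.6-fold higher number from compound 2 to compound 4 (0.20 log units; within the scatter) in this assay. This is the first step shown for a change at this nitrogen, and it is a step within the scatter even though the entering group brings an aromatic ring. The free amino group of compound 2 can therefore carry this sulfonyl group with no difference beyond the scatter in this read-out, and nothing given here offers an explanation for that.

From the compounds shown here alone, whether the same holds on the shorter chain of compound 1 remains open, since compound 1 and compound 4 differ in two places. Also open, going by these compounds, is whether a smaller sulfonyl group such as methanesulfonyl, or a carboxylic acid on the aromatic ring, would give a different number.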